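The source may hold more compounds than are shown below. What is called first, only, known or untested is meant among the compounds shown, and "the series" means these compounds.

Of the compounds shown here, three sharing one core have been tested in a functional assay on HepG2 cells (Homo sapiens) for cytotoxicity, read by MTT assay, with a stated time of 48 h; on this read-out higher numbers stand for weaker inhibition and lower numbers for stronger inhibition. Compound 1 `COc1ccc(CNC(=O)CSc2nc3ccc(NC(=O)c4ccccc4)cc3s2)cc1` gives 12700 nM in this assay, and compound 2 `O=C(CSc1nc2ccc(NC(=O)CCl)cc2s1)NCc1ccc(Cl)cc1` gives 1800 nM. Among the compounds with values here, for compound 3 `O=C(CSc1nc2ccc(NC(=O)c3ccc([N+](=O)[O-])cc3)cc2s1)NCc1ccc(Cl)cc1` this assay reports only a limit, > 100000 nM, so where compound 3 stands is known only as a bound, as the one value among the three that sits at the limit of > 100000 nM in this assay, at which 1 of the 3 values shown sits. Within the data shown here, the only measured step between compounds that differ in a single place is an at least 55-fold higher number from compound 2 to compound 3 (1.74 log units; beyond the scatter), brought about by 4-nitrophenyl in place of chloromethyl on a carbonyl carbon.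

Compound 4 `O=C(CSc1nc2ccc(NC(=O)c3ccccc3)cc2s1)NCc1ccc(Cl)cc1` has not yet been measured. It differs from compound 3 by hydrogen in place of nitro on an aromatic carbon. Because compound 3 is known only as a limit, the step to compound 4 cannot be read off directly. The step from compound 2 to compound 3 does show that putting 4-nitrophenyl on that carbonyl carbon weakened the effect sharply, so taking the nitro away again may recover some of it. Compound 1, which carries the same benzoyl group, gives 12700 nM, and that is the best guide. Compound 4 is therefore expected to give about 20000 nM, somewhere between 5000 nM and 100000 nM. This estimate means an expected step of an at least 5.0-fold lower number from compound 3 to compound 4 (0.69 log units; beyond the scatter).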

Compound 4, half-maximal inhibitory concentration: 30100 nM
Compound 4: the middle estimate sits 1.5-fold (0.18 log units) below what was measured, within the range that was stated.
By their numbers in this assay, from the lowest: compound 2; then compound 1; then compound 4. At a limit, above all of these: compound 3.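

With hydrogen in place of nitro on the aromatic carbon para to a large group, this assay shows an at least 3.3-fold lower number from compound 3 to compound 4 (0.52 log units; beyond the scatter), the first sign that this ring position can change the read-out once the benzoyl group is in place. The size of that step is only a bound, as the entry for compound 3 is a limit and not a number: the limit of > 100000 nM in this assay, at which 1 of the 4 values shown sits. Even without the nitro, the phenyl in place of chloromethyl on the carbonyl carbon gives a 17-fold higher number from compound 2 to compound 4 (1.22 log units; beyond the scatter), which means that a large loss does not need the nitro at all, while the far end of the molecule also counts, with chloro in place of methoxy on an aromatic carbon giving a 2.4-fold higher number from compound 1 to compound 4 (0.37 log units; beyond the scatter).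

On these data alone, whether a plain methyl, an amine or a longer chain on that carbonyl carbon would stay close to compound 2, at 1800 nM, remains open. Also open, as far as these compounds go, are the true size of the nitro step and how a methoxy or an amino group at the same ring position would read compared with hydrogen.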